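Isopropylamino to methylamino: the step to compound 3

The source may hold more compounds than are shown below. What is called first, only, known or untested is meant among the compounds shown, and "the series" means these compounds.

In a functional assay on L02 cells (Homo sapiens) for inhibition, read by Griess assay, with stated times of 1 h and 24 h (on this read-out lower numbers stand for stronger inhibition and higher numbers for weaker inhibition), compound 1 `CCCc1nn(C)c2c(NC(C)C)nc(/C=C/c3cccnc3)nc12` gives 574000 nM as its value. Compound 2 `CC(C)Nc1nc(/C=C/c2ccccc2)nc2ccsc12` shows > 1000000 nM on the same read-out, which is a limit of the assay and not a number. For the measured compounds named here, compound 3 `CNc1nc(/C=C/c2ccccc2)nc2ccsc12` carries methyl in place of isopropyl on a nitrogen on an aromatic ring as its only difference from compound 2. Going by the values given here, no measured pair shows this change, so only a modest move in this assay is expected, towards stronger inhibition if there is any. The expected size is an at least 1.4-fold lower number from compound 2 to compound 3 (0.15 log units; that floor lies within the scatter) as an estimate. For compound 3 the estimated value is 700000 nM with 250000 nM to 1500000 nM as the expected range.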

Compound 3, half-maximal inhibitory concentration: > 1000000 nM
Compound 3 was reported as a limit (the forecaster's own chance of this, stated with the estimate: 50%); middle value at least 1.4-fold (0.15 log units) from the limit.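

Compound 2 and compound 3 are both reported only as limits, so no step can be read between them: the limit of > 1000000 nM in this assay, at which 2 of the 3 values shown sit.

The compounds shown leave open whether methyl in place of isopropyl on a nitrogen on an aromatic ring changes inhibition at all.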